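Chain Length and Hydroxamic Acid Potency in Liver Cells

A few compounds are considered here, and "the series" means these few. Any claim that something is new, unique, unknown or untested is made for them only; others in the source may bear on it.

Compound 1 `Nc1ncnc2c1c(-c1cnc3[nH]ccc3c1)nn2CCCCC(=O)NO`: 36700 nM
Compound 2 `Nc1nc2cc(-c3nn(CCC(=O)NO)c4ncnc(N)c34)ccc2o1`: > 150000 nM
Compound 3 `Nc1ncnc2c1c(-c1cnc3[nH]ccc3c1)nn2CCCCCCC(=O)NO`: 10300 nM

In a functional assay on HepG2 cells (Homo sapiens) for inhibition, read by MTT assay, with a stated time of 72 h (a higher number here means a weaker inhibitor, a lower number a stronger inhibitor), compound 1 gives 36700 nM and compound 3 gives 10300 nM. For compound 2 the assay reports only a limit, > 150000 nM. The difference between the cores of compound 1 and compound 2 is not broken down here. The change from compound 1 to compound 3 is 2-(hydroxycarbamoyl)ethyl in place of hydroxycarbamoyl on a saturated chain carbon, four bonds along the chain from an aromatic nitrogen, and it brought a 3.6-fold lower number from compound 1 to compound 3 (0.55 log units; beyond the scatter). Compound 4 `Nc1nc2cc(-c3nn(CCCCC(=O)NO)c4ncnc(N)c34)ccc2o1` differs from compound 2 by 2-(hydroxycarbamoyl)ethyl in place of hydroxycarbamoyl on a saturated chain carbon, two bonds along the chain from an aromatic nitrogen, the same kind of change, but the place is two bonds along the chain from an aromatic nitrogen rather than four. For compound 4 a step of an at least 2.5-fold lower number from compound 2 to compound 4 (0.39 log units; beyond the scatter) is expected, resting on the step from compound 1 to compound 3 in this assay. The expectation is uncertain because compound 2 sits at the limit of > 150000 nM in this assay, at which 1 of the 3 values shown sits. Compound 4 is therefore estimated at 60000 nM, likely between 20000 nM and 200000 nM.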

Compound 4, half-maximal inhibitory concentration: 2100 nM
For compound 4 the middle estimate is 29-fold (1.46 log units) above the measured one; the whole stated range lies above it.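

The change to 2-(hydroxycarbamoyl)ethyl brings an at least 71-fold lower number from compound 2 to compound 4 (1.85 log units; beyond the scatter) in this assay. The direction of the change carries over from one core to the other, but its size does not: the same change on two cores in this assay, a 3.6-fold lower number (0.55 log units; beyond the scatter) from compound 1 to compound 3 and an at least 71-fold lower number (1.85 log units; beyond the scatter) from compound 2 to compound 4, at least 20-fold (1.30 log units) apart, beyond the scatter of two such steps Compound 2 is known only as a limit, so the full size of this step stays unknown, and a single pair on each core establishes no general rule: the limit of > 150000 nM in this assay, at which 1 of the 4 values shown sits.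

The compounds shown leave open whether a longer chain would lower the number further on either core. They also leave open whether a carboxylic acid in place of hydroxycarbamoyl would give a similar result.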